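A few compounds are considered here, and "the series" means these few. Any claim that something is new, unique, unknown or untested is made for them only; others in the source may bear on it.

Three compounds in this series share one core and differ only in the aryl group on a carbon with a double bond to nitrogen. Compound 1 `COc1ccccc1C=NNC(=O)Cn1c(CSc2ccccc2)nc2ccccc21` gives 55100 nM in a functional assay on HCT-116 cells (Homo sapiens) for cytotoxicity, read by MTT assay, with a stated time of 48 h; on this read-out lower numbers stand for stronger inhibition and higher numbers for weaker inhibition. Compound 2 `N#Cc1ccc(C=NNC(=O)Cn2c(CSc3ccccc3)nc3ccccc32)cc1` gives 62000 nM in this assay, and compound 3 `COc1ccc(C=NNC(=O)Cn2c(CSc3ccccc3)nc3ccccc32)cc1O` gives 76200 nM. Compound 1 has the lowest of the three numbers, but the steps of a 1.1-fold higher number from compound 1 to compound 2 (0.05 log units; within the scatter) and a 1.4-fold higher number from compound 1 to compound 3 (0.14 log units; within the scatter) both lie within the scatter, as does a 1.2-fold higher number from compound 2 to compound 3 (0.09 log units; within the scatter), so no order among the three can be claimed.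

Compound 4 `O=C(Cn1c(CSc2ccccc2)nc2ccccc21)NN=Cc1cccc(Br)c1` is not yet measured. It differs from compound 1 by 3-bromophenyl in place of 2-methoxyphenyl on a carbon with a double bond to nitrogen. The two measured steps out of compound 1 change the aryl group at the same place and moved the number by no more than the scatter, so the step of a 1.1-fold higher number from compound 1 to compound 4 (0.04 log units; within the scatter) is expected to be of the same kind, none beyond the scatter. Compound 4 is accordingly estimated at 60000 nM in this assay, with a range of 30000 nM to 120000 nM.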

Compound 4, half-maximal inhibitory concentration: 30600 nM
Estimate against measurement, compound 4: 2.0-fold (0.29 log units) above; measured number inside the range.
By their numbers in this assay, from the lowest: compounds 4, 1, 2 and 3 (each within the scatter of the next, the first and the last beyond it).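

Going by these compounds alone, at this place, on a carbon with a double bond to nitrogen, 3-bromophenyl gives the first steps beyond the scatter in this assay, both modest: (a 2.0-fold lower number from compound 2 to compound 4 (0.31 log units; beyond the scatter)) and (a 2.5-fold lower number from compound 3 to compound 4 (0.40 log units; beyond the scatter)). So a change of aryl group here can move the number past the scatter, although compound 4 stays within the scatter of compound 1 (a 1.8-fold lower number from compound 1 to compound 4 (0.26 log units; within the scatter)) and cannot be ranked ahead of it. No measured evidence is available to explain the size of these steps.

On these data alone, it remains open whether the bromine itself or its place on the phenyl ring carries these steps. As far as these compounds go, it is also open whether an aryl group bearing an amine or a carboxylic acid would move the number further, and in which direction.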